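Swapping a tert-butylphenyl for naphthalene on the amine arm

This account rests on a few compounds, and the source may have more. Where it says the series, first, only, none or still open, it means among the compounds named here.

Of the compounds shown here, three that share one core have been tested in a functional assay on MCF7 cells (Homo sapiens) for inhibition, read by MTT assay, with a stated time of 72 h; a higher number here means a weaker inhibitor of growth, a lower number a stronger inhibitor of growth. Compound 1 `O=S(=O)(NCCCNCc1ccccc1Cl)c1cc(C(F)(F)F)cc(C(F)(F)F)c1` gives 8800 nM, compound 2 `CC(C)(C)c1ccc(CNCCCNS(=O)(=O)c2cc(C(F)(F)F)cc(C(F)(F)F)c2)cc1` gives 2100 nM, and compound 3 `O=S(=O)(NCCCNCc1ccc(Br)cc1)c1cc(C(F)(F)F)cc(C(F)(F)F)c1` gives 1900 nM. Compound 2 stands second highest of these three numbers: its value and that of compound 3 lie within the scatter of each other, while the step of a 4.2-fold lower number from compound 1 to compound 2 (0.62 log units; beyond the scatter) and the step of a 4.6-fold lower number from compound 1 to compound 3 (0.67 log units; beyond the scatter) both go beyond it. Compound 4 `O=S(=O)(NCCCNCc1cccc2ccccc12)c1cc(C(F)(F)F)cc(C(F)(F)F)c1` differs from compound 2 by naphthalen-1-yl in place of 4-(tert-butyl)phenyl on a saturated chain carbon bound to an amine nitrogen. Going by the values given here, no measured step places a second fused ring on this arm; the two steps that bear on it, a 4.2-fold lower number from compound 1 to compound 2 (0.62 log units; beyond the scatter) and a 4.6-fold lower number from compound 1 to compound 3 (0.67 log units; beyond the scatter), only show that changing the aryl group here can move the number by a modest amount, while a 1.1-fold lower number from compound 2 to compound 3 (0.04 log units; within the scatter) shows a change on the aromatic carbon can also leave it unchanged. A modest step in this assay, of uncertain direction, is therefore expected, with a slight lean toward a higher number. Compound 4 is estimated at 3500 nM, between 1200 nM and 10000 nM, which means an expected step of a 1.7-fold higher number from compound 2 to compound 4 (0.22 log units; within the scatter).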

Compound 4, concentration for 50% growth inhibition: 1400 nM
Beside the measured number, compound 4's estimate is 2.5-fold (0.40 log units) above it, and the stated range covers the measured number.
By their numbers in this assay, from the lowest: compounds 4, 3 and 2 (each within the scatter of the next); then compound 1.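

Going by these compounds alone, the naphthalen-1-yl group gives the first reading of a second fused ring on this arm, and in this assay it cannot be told apart from the single-ring groups of compound 2 (a 1.5-fold lower number from compound 2 to compound 4 (0.18 log units; within the scatter)) or compound 3 (a 1.4-fold lower number from compound 3 to compound 4 (0.13 log units; within the scatter)). Compound 1, with its 2-chlorophenyl group, now stands apart from all three other compounds, including the new one (a 6.3-fold lower number from compound 1 to compound 4 (0.80 log units; beyond the scatter)). No measurement shown accounts for this outcome.

On these data alone, what a pyridine ring or a naphthalen-2-yl group would do on this arm remains open, as does the effect of a longer chain in the shared core. As far as these compounds go, all four compounds carry an aromatic group here, so a saturated ring such as cyclohexyl also remains untested in these data.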